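The source may hold more compounds than are shown below. What is called first, only, known or untested is meant among the compounds shown, and "the series" means these compounds.

Compound 1, `COc1cc(O)c([C@@H]2CC(=O)c3c(O)cc(O)cc3O2)cc1C/C=C(\C)CCC=C(C)C`, is a limit in a functional assay on MCF7 cells (Homo sapiens) for cytotoxicity, with a stated time of 72 h; a lower number here means that less compound is needed, a higher number that more compound is needed for the effect: in this assay compound 1 gives > 10000 nM.
Compound 2, `C=C(C)C(O)CC/C(C)=C/Cc1c(O)cc2c(c1O)C(=O)C[C@@H](c1ccc(O)c(OC)c1)O2`, is likewise a limit: in this assay compound 2 gives > 10000 nM.

Among the measured compounds shown here, compound 2 therefore stands at a limit rather than at a number, and the one further value shown is also a limit, so the whole picture rests on (the limit of > 10000 nM in this assay, at which 2 of the 2 values shown sit). Compound 3, `COc1cc([C@@H]2CC(=O)c3c(cc(O)c(C/C=C(\C)C/C=C/C(C)(C)O)c3O)O2)ccc1O`, has not yet been measured in this assay. It differs from compound 2 in one place: 3-hydroxy-3-methylbut-1-en-1-yl in place of 2-hydroxy-3-methylbut-3-en-1-yl on a saturated chain carbon bound to a double-bonded chain carbon. The two compounds hold the same atoms, joined differently, and the hydroxyl moves within the chain of the same length. For the measured compounds named here, no step between two measured compounds is available to gauge such a change, so no shift beyond the usual scatter is expected. Compound 3 is estimated at 15000 nM, within 5000 nM to 50000 nM. The expected step is a step that the limit leaves unreadable from compound 2 to compound 3, and a further limit rather than a number is the likely outcome for compound 3.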

Compound 3, half-maximal effective concentration: > 10000 nM
Compound 3: a limit, no number; the forecaster's own chance of this, stated with the estimate: 80%; the middle value does not contradict the limit.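

In this assay compound 3 gives > 10000 nM, a limit and not a number. Among the compounds shown here, compound 2 also stands at a limit, so no step from compound 2 to compound 3 can be read. The compounds shown leave open whether moving the hydroxyl within the chain changes the effect at all: the limit of > 10000 nM in this assay, at which 3 of the 3 values shown sit.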